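Dropping the Ether Oxygen on the Way to Compound 4

The source may report more compounds than this note shows. Statements on the series, on what has been measured and on what is new or still open speak of the compounds shown alone.

Of the compounds shown here, three sharing one core have been tested in a functional assay on CHO cells for agonist activity at Free fatty acid receptor 1 (Homo sapiens), read by FLIPR and calcium flux, tested at 1 uM; a higher number here means that more compound is needed for the effect, a lower number that less compound is needed. Compound 1 `O=C(O)CCc1ccc(NC(=O)c2nnc(COc3ccc4c(c3)CCC4)s2)cc1` gives 1380 nM, compound 2 `Cc1cccc(OCc2nnc(C(=O)Nc3ccc(CCC(=O)O)cc3)s2)c1` gives 3260 nM, and compound 3 `CCc1ccc(OCc2nnc(C(=O)Nc3ccc(CCC(=O)O)cc3)s2)cc1` gives 1170 nM, the lowest of the three, although compound 1 sits within the scatter of it. The change to compound 4 `O=C(O)CCc1ccc(NC(=O)c2nnc(Cc3cccc(F)c3)s2)cc1` is 3-fluorophenyl in place of 4-ethylphenoxy on a saturated chain carbon bound to an aromatic carbon. The measured steps all swap one aromatic group for another while keeping the oxygen: a 2.4-fold higher number from compound 1 to compound 2 (0.37 log units; beyond the scatter), a 2.8-fold lower number from compound 2 to compound 3 (0.45 log units; beyond the scatter), and a 1.2-fold lower number from compound 1 to compound 3 (0.07 log units; within the scatter). As far as these compounds go, none of them removes the oxygen, so that part of the change is untested. Those swaps were at most modest. A modest step in this assay is therefore expected for compound 4, most likely toward a higher number, roughly a 2.1-fold higher number from compound 3 to compound 4 (0.33 log units; beyond the scatter). Compound 4 is estimated at 2500 nM, between 800 nM and 8000 nM.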

Compound 4, half-maximal effective concentration: 5020 nM
Compound 4: middle estimate off by 2.0-fold (0.30 log units), on the low side; low and high end bracket the measured number.
By their numbers in this assay, from the lowest: compounds 3 and 1 (each within the scatter of the next); then compounds 2 and 4 (each within the scatter of the next).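

In this assay, placing 3-fluorophenyl on this saturated chain carbon gives a 4.3-fold higher number from compound 3 to compound 4 (0.63 log units; beyond the scatter) and a 3.6-fold higher number from compound 1 to compound 4 (0.56 log units; beyond the scatter) while a 1.5-fold higher number from compound 2 to compound 4 (0.19 log units; within the scatter) stays within the scatter. The size of the step therefore depends on which oxygen-linked group leaves. Nothing here gives a reason for these steps.

The oxygen and the ring substituent change together in every step to compound 4, so which of them accounts for the shift stays open. As far as these compounds go, how an amine or a longer chain on this carbon would read is also open.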